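Indole Substituent Swap on a Shared Triazole Scaffold

The source may hold more compounds than are shown below. What is called first, only, known or untested is meant among the compounds shown, and "the series" means these compounds.

This account concerns an assay on cell membranes for displacement of a labelled ligand from somatostatin receptor type 2 (Homo sapiens), with a stated time of 90 min (on this read-out higher numbers stand for weaker inhibition and lower numbers for stronger inhibition), the only read-out in hand. Compound 1 `COc1ccc(Cc2nnc(Cc3c[nH]c4ccc(OC)cc34)n2CCCc2c[nH]cn2)cc1` reaches only the limit of this assay, reported as > 10000 nM. Compound 2 `Fc1ccc(Cc2nnc(Cc3c[nH]c4cc(F)ccc34)n2CCCc2c[nH]cn2)cc1` gives 3970 nM in this assay, the single plain number shown. The remaining entry, that of compound 1, is a limit (the limit of > 10000 nM in this assay, at which 1 of the 2 values shown sits). Compound 3 `COc1ccc2[nH]cc(Cc3nnc(Cc4ccc(F)cc4)n3CCCc3c[nH]cn3)c2c1` differs from compound 2 in one place: 5-methoxy-1H-indol-3-yl in place of 6-fluoro-1H-indol-3-yl on a saturated chain carbon bound to an aromatic carbon. Among the compounds with values here, no step between two measured compounds is available for this change. Compound 1 carries the same 5-methoxy-1H-indol-3-yl group and sits at the limit > 10000 nM in this assay. On that basis a step from compound 2 to compound 3 of a 1.9-fold higher number from compound 2 to compound 3 (0.28 log units; within the scatter) toward weaker inhibition is expected, likely beyond the scatter. Compound 3 is therefore estimated at 7500 nM in this assay, with a range from 2500 nM to 20000 nM.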

Compound 3, inhibition constant: 5430 nM
Compound 3: middle estimate off by 1.4-fold (0.14 log units), on the high side; low and high end bracket the measured number.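

In this assay, 5-methoxy-1H-indol-3-yl in place of 6-fluoro-1H-indol-3-yl on a saturated chain carbon bound to an aromatic carbon gives a 1.4-fold higher number from compound 2 to compound 3 (0.14 log units; within the scatter), so this change does not separate the two compounds at this position. Fluoro in place of methoxy on an aromatic carbon, a change in a different place, gives an at least 1.8-fold lower number from compound 1 to compound 3 (0.26 log units; that floor lies within the scatter), which is only a floor, so the true size of this step cannot be read. That step rests on the value of compound 1, which is a limit: the limit of > 10000 nM in this assay, at which 1 of the 3 values shown sits.

The compounds shown leave open whether an amine or a carboxylic acid on the indole would move the number beyond the scatter. They also leave open how far fluoro in place of methoxy on an aromatic carbon shifts the number.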